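The source may report more compounds than this note shows. Statements on the series, on what has been measured and on what is new or still open speak of the compounds shown alone.

Measured compounds in a functional assay on the whole organism (artery, strain albino) with Rattus norvegicus as the target, with a stated time of 900 min, at a dose of 10 mg/kg by the oral route; a lower number here means less inhibition, a higher number more inhibition at the dose given (going by the name of the read-out):
- compound 1, `COc1ccc(C2N=C(SCc3ccccc3Cl)NC(C)=C2C(=O)Nc2ccc(F)cc2)cc1OC`: 21%
- compound 2, `COc1ccc(C2N=C(SCc3cccc(Cl)c3)NC(C)=C2C(=O)Nc2ccc(F)cc2)cc1OC`: 13.3%
- compound 3, `CC1=C(C(=O)Nc2ccc([N+](=O)[O-])cc2)C(c2cccc([N+](=O)[O-])c2)N=C(SCc2ccccc2Cl)N1`: 7.2%

Compound 1 and compound 2 share a core and differ by one change, (3-chlorophenyl in place of 2-chlorophenyl on a saturated chain carbon bound to a sulfur). The step of a number 7.7 percentage points lower from compound 1 to compound 2 (within the scatter) stays within the scatter, so the two values cannot be told apart with confidence. Compound 3 sits on a different core; the difference between the core of compound 3 and the core of compound 1 is not broken down here. Compound 3 gives the lowest of the three numbers, within the scatter of compound 2 and beyond it only against compound 1.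

Compound 4, `CC1=C(C(=O)Nc2ccc([N+](=O)[O-])cc2)C(c2cccc([N+](=O)[O-])c2)N=C(SCc2cccc(Cl)c2)N1`, is not yet measured. It differs from compound 3 by 3-chlorophenyl in place of 2-chlorophenyl on a saturated chain carbon bound to a sulfur, the same change as between compound 1 and compound 2, at the same place. The step from compound 3 to compound 4 is expected to be small, about a number 3.2 percentage points lower from compound 3 to compound 4 (within the scatter), because the earlier step of a number 7.7 percentage points lower from compound 1 to compound 2 (within the scatter) was within the scatter. Compound 4 is therefore estimated at 4%, with a likely span from -10% to 18%.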

Compound 4, a percentage reported as inhibition, in the whole organism at one dose (the size of the read-out at that dose, not a potency): 10.8%
Beside the measured number, compound 4's estimate is 6.8 percentage points below it; measured number inside the range.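

In this assay, 3-chlorobenzyl in place of 2-chlorobenzyl on the sulfur gives a number 3.6 percentage points higher from compound 3 to compound 4 (within the scatter), so on the core of compound 3, as on the core of compound 1, the two chlorobenzyl groups cannot be told apart. This does not show that the change has any real effect on either core, and two cores say nothing about how it would behave on a third. Within these limits, the change can be carried from one core to the other without a step that stands out, and the two steps do not differ from each other:  the same change on two cores in this assay, a number 7.7 percentage points lower (within the scatter) from compound 1 to compound 2 and a number 3.6 percentage points higher (within the scatter) from compound 3 to compound 4, 11.3 percentage points apart, within the scatter of two such steps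

The compounds shown hold only a chlorobenzyl group at this place, so what an amine, a carboxylic acid or a longer chain on a saturated chain carbon bound to a sulfur would do in this assay stays open. Also open, from the compounds shown here alone, is which of the other differences between the two cores matters, since these are not broken down one at a time.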